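The source may report more compounds than this note shows. Statements on the series, on what has been measured and on what is new or still open speak of the compounds shown alone.

In a functional assay on BXPC-3 cells (Homo sapiens) for inhibition, read by MTT assay, with a stated time of 72 h (a lower number here means a stronger inhibitor of growth, a higher number a weaker inhibitor of growth), compound 2 `COc1ccc(CNCCCNS(=O)(=O)c2cc(C(F)(F)F)cc(C(F)(F)F)c2)cc1OC` gives 13000 nM, the higher of the two numbers in hand. Compound 1 `O=S(=O)(NCCNCc1ccc(-c2ccccc2)cc1)c1cc(C(F)(F)F)cc(C(F)(F)F)c1` gives 1600 nM in the same assay, and the two values lie apart beyond the scatter. Compound 3 `O=S(=O)(NCCCNCc1ccc(C(F)(F)F)cc1)c1cc(C(F)(F)F)cc(C(F)(F)F)c1` is built from compound 2 by a single exchange: 4-(trifluoromethyl)phenyl in place of 3,4-dimethoxyphenyl on a saturated chain carbon bound to an amine nitrogen. Among the measured compounds shown here, no measured pair shows this exact exchange, so its size must be judged from the two values in hand alone. Compound 3 is expected to move toward a lower number, a step of a 2.9-fold lower number from compound 2 to compound 3 (0.46 log units; beyond the scatter), because compound 1 gives 1600 nM with another aryl group on that same chain carbon. The estimate for compound 3 is 4500 nM, within a range from 1500 nM to 13000 nM.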

Compound 3, concentration for 50% growth inhibition: 1700 nM
Estimate against measurement, compound 3: 2.6-fold (0.42 log units) above; low and high end bracket the measured number.
By their numbers in this assay, from the lowest: compounds 1 and 3 (each within the scatter of the next); then compound 2.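

In this assay, among the compounds shown here, the exchange of 3,4-dimethoxyphenyl for 4-(trifluoromethyl)phenyl on a saturated chain carbon bound to an amine nitrogen gives a 7.6-fold lower number from compound 2 to compound 3 (0.88 log units; beyond the scatter) and is the only single exchange measured here. It shows that, with the rest of compound 2 held fixed, the aryl group at this position alone moves the number beyond the scatter. Nothing at hand explains this step. The compounds shown leave open whether the step comes from losing the two methoxy groups or from gaining the trifluoromethyl group. Plain phenyl or 4-methoxyphenyl at this position would separate the two.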